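From 3-hydroxyphenyl to 3-bromo-4-hydroxyphenyl on the shared core

The compounds below may be only part of what the source reports. "The series", "measured", "known", "first", "only" and "open" are said of these compounds alone.

In a functional assay on SK-OV-3 cells (Homo sapiens) for antiproliferative activity, read by MTT assay, with a stated time of 24 h (on this read-out higher numbers stand for weaker inhibition and lower numbers for stronger inhibition), compound 1 (`COc1ccc(/C=C/C(=O)c2ccc(OC)c3c2OC(C)(C)C=C3)c(F)c1`) gives 4880 nM and compound 2 (`COc1ccc(C(=O)/C=C/c2ccc([N+](=O)[O-])cc2)c2c1C=CC(C)(C)O2`) gives 3420 nM with a 1.4-fold lower number from compound 1 to compound 2 (0.15 log units; within the scatter) between them.

Compound 3 (`COc1ccc(C(=O)/C=C/c2cccc(O)c2)c2c1C=CC(C)(C)O2`) carries > 10000 nM in this assay and this is a limit and not a number.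

Going by the values given here, two measured steps bear on the next change: an at least 2.0-fold higher number from compound 1 to compound 3 (0.31 log units; beyond the scatter) and an at least 2.9-fold higher number from compound 2 to compound 3 (0.46 log units; beyond the scatter) are both bounds and not exact sizes. Among the compounds with values here, compound 3 is the only measured compound with a hydroxyphenyl ring, and no measured compound carries a bromine.

Compound 4 (`COc1ccc(C(=O)/C=C/c2ccc(O)c(Br)c2)c2c1C=CC(C)(C)O2`) differs from compound 3 by 3-bromo-4-hydroxyphenyl in place of 3-hydroxyphenyl on a double-bonded chain carbon bound to a double-bonded chain carbon and the new ring stands on the same double-bonded chain carbon bound to a double-bonded chain carbon. The hydroxyl stays in the entering group, so compound 4 is expected to remain closer to compound 3 than to the numbers of the other two, and it may also reach the limit. A modest move towards a lower number is the working expectation in this assay and could prove to be none beyond the scatter. The estimated step is an at least 1.4-fold lower number from compound 3 to compound 4 (0.15 log units; that floor lies within the scatter) and it is uncertain.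

Compound 4 is expected at 7000 nM with an estimated range of 3000 nM to 15000 nM as a working figure.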

Compound 4, half-maximal inhibitory concentration: > 10000 nM
Compound 4 gave a limit, no number (the forecaster's own chance of this, stated with the estimate: 35%); middle value at least 1.4-fold (0.15 log units) away from the limit.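

In this assay, compound 4 sits at a limit, as compound 3 does, so a second hydroxyphenyl ring on the double-bonded chain carbon bound to a double-bonded chain carbon, this one also carrying bromine, again yields no exact number. Against the two rings without a hydroxyl, the separation holds, with an at least 2.9-fold higher number from compound 2 to compound 4 (0.46 log units; beyond the scatter) and an at least 2.0-fold higher number from compound 1 to compound 4 (0.31 log units; beyond the scatter), both bounds and not exact sizes. Across the four compounds, limits appear only with the two hydroxyl-bearing rings, and the step from compound 3 to compound 4 cannot be read because both ends are limits: the limit of > 10000 nM in this assay, at which 2 of the 4 values shown sit.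

As far as these compounds go, whether the limit goes with the hydroxyl itself stays open, and a 3-aminophenyl ring at this place would test that. From the compounds shown here alone, how far compound 3 and compound 4 lie beyond the limit also stays open, so any effect of the bromine on this read-out remains unknown.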